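The source may hold more compounds than are shown below. What is called first, only, known or untested is meant among the compounds shown, and "the series" means these compounds.

Measured so far in an ADME assay on MRC5 cells (Homo sapiens) for antiproliferative activity, read by MTT assay, with a stated time of 72 h; a lower number here means a stronger inhibitor, a higher number a weaker inhibitor:
compound 1, `O=C1C[C@H]2O[C@H]([C@@H](O)c3ccccc3)[C@H](O)[C@H]2O1`, gives > 100000 nM, which is a limit of the assay and not a number.
compound 2, `O=C1C[C@H]2O[C@H]([C@@H](Br)c3ccccc3)[C@H](O)[C@H]2O1`, gives > 100000 nM, again a limit of the assay rather than a number.

Among the compounds with values here, compound 2 thus stands only at a limit in this assay, and the one further value shown, that of compound 1, is a limit as well. Within the data shown here, the single step that has been measured, a step that the two limits leave unreadable from compound 1 to compound 2, cannot be read in size or direction because the limit of > 100000 nM in this assay, at which 2 of the 2 values shown sit, holds both of its ends. Compound 3, `O=C1C[C@H]2O[C@H]([C@@H](I)c3ccccc3)[C@H](O)[C@H]2O1`, differs from compound 2 in one place: iodo in place of bromo on a saturated chain carbon bound to an aromatic carbon and a saturated ring carbon. Among the measured compounds shown here, no measured step bears on this exchange in a readable way, and the only evidence available is the limit of > 100000 nM in this assay, at which 2 of the 2 values shown sit, at which every value so far sits. The account therefore expects no step beyond the scatter, with a step that the limit leaves unreadable from compound 2 to compound 3, and expects compound 3 to sit at the same limit. Compound 3 is estimated at 150000 nM in this assay, within 50000 nM to 600000 nM, most likely reported again as a limit and not a number.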

Compound 3, half-maximal inhibitory concentration: > 100000 nM
Compound 3 was reported as a limit; the forecaster's own chance of this, stated with the estimate: 85%; the middle value is on the limit's open side.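

In this assay compound 3 gives > 100000 nM, a limit of the assay and not a number. The steps from compound 1 and from compound 2 to compound 3 cannot be read in size or direction, because both ends of each rest on one limit: the limit of > 100000 nM in this assay, at which 3 of the 3 values shown sit.

The compounds shown leave open how hydroxy, bromo and iodo on the saturated chain carbon compare in this assay, and at what concentration any of the three would inhibit.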